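The source may hold more compounds than are shown below. What is called first, only, known or untested is meant among the compounds shown, and "the series" means these compounds.

In a physicochemical assay for solubility, in phosphate buffer, at pH 7.4 (a lower number here means a less soluble compound, a higher number a more soluble compound), compound 1 (`CCOC(=O)c1c(-c2ccc(C(F)(F)F)cc2)[nH]c2cccc(OC)c2c1=O`) gives 22000 nM and compound 2 (`CCOC(=O)c1c(-c2cccc(C)c2)[nH]c2cc(OC)ccc2c1=O`) gives 48000 nM as the higher of the two numbers, a gap beyond the usual scatter. Compound 3 (`CCOC(=O)c1c(-c2ccc(OC)cc2)[nH]c2cc(OC)ccc2c1=O`) carries 4-methoxyphenyl in place of the 3-methylphenyl of compound 2 on an aromatic carbon (4-methoxyphenyl in place of 3-methylphenyl on an aromatic carbon). For the measured compounds named here, no two measured compounds differ in only one place, so nothing measured so far isolates this swap. The expected change (a 1.1-fold lower number from compound 2 to compound 3 (0.06 log units; within the scatter)) stays within the scatter of this assay and has no clear direction. The estimate for compound 3 is 42000 nM (expected range 15000 nM to 100000 nM).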

Compound 3, solubility: 8000 nM
Compound 3: the middle estimate sits 5.3-fold (0.72 log units) above what was measured; the whole stated range lies above it.
By their numbers in this assay, from the lowest: compound 3; then compound 1; then compound 2.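

In this assay there is a 6.0-fold lower number from compound 2 to compound 3 (0.78 log units; beyond the scatter) when 4-methoxyphenyl replaces 3-methylphenyl on the aromatic carbon next to the ring nitrogen, with the rest of the molecule unchanged. This shows that the number responds to the aryl group at this position, which the earlier pair, differing in more than one place, could not show. Nothing available explains the change.

The step alters both the substituent and its place on the phenyl ring, and these cannot be separated here. Going by these compounds, how 4-methylphenyl, 3-methoxyphenyl or a phenyl ring bearing a carboxylic acid or an amine would compare remains open.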